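Amide series: swapping the ring amine on compound 1

The source may report more compounds than this note shows. Statements on the series, on what has been measured and on what is new or still open speak of the compounds shown alone.

Among the compounds with values here, compound 1 `Cc1cc(N(C)C)nc2ccc(NC(=O)c3ccc(Cl)c(Cl)c3)cc12` is the weaker of the two measured members: in a functional assay on MCF7 cells (Homo sapiens) for antiproliferative activity, read by MTT assay, with a stated time of 72 h (on this read-out higher numbers stand for weaker inhibition and lower numbers for stronger inhibition), compound 1 gives 33300 nM, whereas compound 2 `CCN1CCN(c2cc(C)c3cc(NC(=O)c4ccccc4OC)ccc3n2)CC1` gives 13200 nM in this assay, a gap beyond the scatter. Compound 3 `CCNc1cc(C)c2cc(NC(=O)c3ccc(Cl)c(Cl)c3)ccc2n1` has not been tested. It differs from compound 1 only by ethylamino in place of dimethylamino on an aromatic carbon. Within the data shown here, no measured pair isolates this change, so the expectation rests on the structural similarity alone: a small step, if any, most likely within the scatter, with a slight lean toward stronger inhibition. On that basis the estimated step is a 1.3-fold lower number from compound 1 to compound 3 (0.12 log units; within the scatter). Compound 3 is expected to give about 25000 nM in this assay, plausibly between 10000 nM and 60000 nM.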

Compound 3, half-maximal inhibitory concentration: 48600 nM
Beside the measured number, compound 3's estimate is 1.9-fold (0.29 log units) below it, within the range that was stated.
By their numbers in this assay, from the lowest: compound 2; then compounds 1 and 3 (each within the scatter of the next).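

At this position on an aromatic carbon next to the ring nitrogen, ethylamino in place of dimethylamino, with the same heavy-atom count and one hydrogen-bond donor entering, gives a 1.5-fold higher number from compound 1 to compound 3 (0.16 log units; within the scatter) in this assay. The two isomeric amines therefore cannot be told apart on this read-out, and the donor on ethylamino brings no step beyond the scatter. No measurement at hand bears on why the two amines read alike.

Still open, on these data alone, is how this position responds to a larger change, such as a free amino group or a longer chain like butylamino, on the same dichlorobenzamide.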